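Cutting compound 3's side chain back to a plain amide

This account rests on a few compounds, and the source may have more. Where it says the series, first, only, none or still open, it means among the compounds named here.

Compound 1 `CNC(=O)c1cc(C(=O)NC2CC2)cn(Cc2ccc(F)cc2)c1=O`: >= 162 ug/mL
Compound 2 `CNC(=O)c1cc(C(=O)NC2CC2)cn(Cc2ccc(C)cc2)c1=O`: 24 ug/mL
Compound 3 `CNC(=O)c1cc(C(=O)NCCC2CCOCC2)cn(Cc2ccccc2)c1=O`: >= 127 ug/mL

The read-out here is a physicochemical assay for solubility; a higher number here means a more soluble compound, a lower number a less soluble compound. Compound 3 gives >= 127 ug/mL, and this value is a limit, not a number. Compound 1 gives >= 162 ug/mL, which is also a limit.

Compound 4 `CNC(=O)c1cc(C(N)=O)cn(Cc2ccccc2)c1=O` is not yet measured. It differs from compound 3 in one place: hydrogen in place of 2-(oxan-4-yl)ethyl on an amide-type nitrogen. The whole 2-(oxan-4-yl)ethyl group goes, and hydrogen takes its place on the amide-type nitrogen.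

Going by the values given here, only one measured step is available, an at least 6.7-fold lower number from compound 1 to compound 2 (0.82 log units; beyond the scatter). That step is methyl in place of fluoro on an aromatic carbon, not a change on an amide-type nitrogen, so it offers no direct guide to direction. It does show that one swap can move this assay beyond the scatter, so the range has to stay wide. The expected step is an at least 1.1-fold lower number from compound 3 to compound 4 (0.06 log units; that floor lies within the scatter), which means no clear change is expected beyond the scatter. For compound 4 the estimate is 110 ug/mL, with an expected range from 35 ug/mL to 250 ug/mL.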

Compound 4, solubility: 71 ug/mL
For compound 4 the middle estimate is 1.5-fold (0.19 log units) above the measured one; the measured number falls inside the stated range.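

Going by these compounds alone, the first reading at this amide-type nitrogen in this assay is an at least 1.7-fold lower number from compound 3 to compound 4 (0.25 log units; that floor lies within the scatter) for the loss of the whole 2-(oxan-4-yl)ethyl group. The compounds therefore show no drop beyond the scatter on cutting back to the plain amide, though a larger drop is not ruled out. The true size of the step stays unknown, because compound 3 carries a limit and not a number: the limit of >= 127 ug/mL in this assay, at which 1 of the 4 values shown sits.

Still open, as far as these compounds go, is whether any difference belongs to the oxane ring or to the chain that holds it. Also open, from the compounds shown here alone, is how a plain ethyl chain, or a chain ending in an amine or a carboxylic acid, on this nitrogen would read in this assay against compound 4.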